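A few compounds are considered here, and "the series" means these few. Any claim that something is new, unique, unknown or untested is made for them only; others in the source may bear on it.

Compound 1 `CC(C)(C)C(=O)C1=C(O)C(=O)N(c2ccc(-c3ccon3)cc2)C1c1ccccc1OCCO` was measured in an ADME assay on the whole organism (Rattus norvegicus) for pharmacokinetics (a lower number here means slower removal, a higher number faster removal of the compound), where compound 1 gives 2.9 mL/min/kg. Compound 2 `CC(C)(C)C(=O)C1=C(O)C(=O)N(c2ccc(-c3ccoc3)cc2)C1c1ccccc1OCCO` was also submitted to this assay, but for compound 2 the reported result is "not determined" (no result reported), so compound 2 stands nowhere on the numbers and cannot be set against compound 1. Compound 3 `CC(C)(C)C(=O)C1=C(O)C(=O)N(c2ccc(-c3cccs3)cc2)C1c1ccccc1OCCO` is the next compound and differs from compound 2 in a single place, (thiophen-2-yl in place of furan-3-yl on an aromatic carbon). Among the compounds with values here, no step between measured compounds exists for this change, so its size and direction in this assay are unknown; the leaving and entering groups are closely alike in what is counted for them, and a shift that stays within the usual scatter of the assay seems the most likely outcome, in either direction. Compound 3 is therefore expected to show a clearance of about 4 mL/min/kg, with a likely range from 1.5 mL/min/kg to 12 mL/min/kg.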

Compound 3, clearance: 1.3 mL/min/kg
For compound 3 the middle estimate is 3.1-fold (0.49 log units) above the measured one; measured number below the stated range.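

Within the data shown here, the first readable step at this position is a 2.2-fold lower number from compound 1 to compound 3 (0.35 log units; beyond the scatter) in this assay, with thiophen-2-yl in place of 1,2-oxazol-3-yl, and it lies modestly beyond the usual scatter. Exchanging one five-membered aromatic ring for another on this aromatic carbon can therefore move the clearance, whereas the step involving furan-3-yl cannot be read: compound 2 carries no number. No measurement at hand explains the shift.

Among these compounds, with only two numbers, it remains open whether the shift follows the sulfur atom, the point at which the ring is attached, or the change in the ring's hetero atoms. The compounds also leave open how the clearance would respond to a six-membered pyridine ring, an amine or a carboxylic acid on this carbon.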